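The source may hold more compounds than are shown below. What is called first, only, known or untested is meant among the compounds shown, and "the series" means these compounds.

In a functional assay on MKN-45 cells (Homo sapiens) for cytotoxicity, read by MTT assay, with a stated time of 72 h (a lower number here means a stronger inhibitor, a higher number a weaker inhibitor), compound 2 (`COc1cc2c(Oc3ccc(NC(=O)c4nccc(-c5ccc(F)cc5)n4)cc3F)ccnc2cc1OCCCN1CCN(C)CC1`) gives 90 nM, the lowest of the two numbers in hand. Within the data shown here, compound 1 (`COc1cc2c(Oc3ccc(NC(=O)c4nccc(-c5ccc(F)cc5F)n4)cc3F)ccnc2cc1OCCCN1CCCCC1`) gives 1120 nM in this assay, a far higher number; the two differ in more than one place, so their values show only that compound 2 is the stronger of the pair. Compound 3 (`COc1cc2c(Oc3ccc(NC(=O)c4nccc(-c5ccc(F)cc5F)n4)cc3F)ccnc2cc1OCCCN1CCN(C)CC1`) is not yet measured. It differs from compound 2 by fluoro in place of hydrogen on an aromatic carbon, so that compound 3 carries the 2,4-difluorophenyl group of compound 1 together with the chain and ring of compound 2. Among the measured compounds shown here, with no single-point step available to calibrate the change, the expectation for compound 3 rests on the spread between these two measured values, and the step of a 2.8-fold higher number from compound 2 to compound 3 (0.44 log units; beyond the scatter) is estimated as a moderate loss of potency, beyond the scatter but well short of the gap to compound 1. Compound 3 is expected to give 250 nM in this assay, within a range of 70 nM to 900 nM.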

Compound 3, half-maximal inhibitory concentration: 440 nM
For compound 3 the middle estimate is 1.8-fold (0.25 log units) below the measured one, within the range that was stated.
By their numbers in this assay, from the lowest: compound 2; then compound 3; then compound 1.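

In this assay, among these compounds, the step of a 4.9-fold higher number from compound 2 to compound 3 (0.69 log units; beyond the scatter) gives the first single-change reading at this position: going from 4-fluorophenyl to 2,4-difluorophenyl, with the new fluoro ortho to a large group, raises the number beyond the scatter. With the 2,4-difluorophenyl group held fixed, the step of a 2.5-fold lower number from compound 1 to compound 3 (0.41 log units; beyond the scatter) shows that 4-methylpiperazin-1-yl in place of piperidin-1-yl lowers the number, so each of the two changes separating compound 1 from compound 2 moves the number beyond the scatter. No measurement at hand explains either step.

Going by these compounds, whether this fluoro would cost as much with piperidin-1-yl on the chain stays open, as does how a chloro or methoxy group at the same place would read. Also open, on these data alone, is how a morpholine ring, a dimethylamino group or a longer chain would compare with 4-methylpiperazin-1-yl.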